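A methyl group added to an inactive pair

The source may hold more compounds than are shown below. What is called first, only, known or untested is meant among the compounds shown, and "the series" means these compounds.

Measured compounds:
compound 1 `O=C1CS/C(=N\c2csc(-c3ccc(Cl)cc3)c2)N1c1ccc(Cl)cc1` — > 50000 nM
compound 2 `O=C1CS/C(=N\c2csc(-c3ccc(Cl)cc3)c2)N1c1ccccc1` — > 50000 nM

In a functional assay on MCF7 cells (Homo sapiens) for cytotoxicity, read by MTT assay, with a stated time of 72 h (a lower number here means a stronger inhibitor, a higher number a weaker inhibitor), compound 1 gives > 50000 nM, which is a limit of the assay rather than a number. Compound 2 gives > 50000 nM in this assay, again only a limit. Among the measured compounds shown here, the single step between them, a step that the two limits leave unreadable from compound 1 to compound 2, therefore has no readable size; both values sit at the limit of > 50000 nM in this assay, at which 2 of the 2 values shown sit. Compound 2 thus stands at the limit of this assay, with no number that places it relative to compound 1.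

Compound 3, `Cc1ccc(N2C(=O)CS/C2=N\c2csc(-c3ccc(Cl)cc3)c2)cc1`, differs from compound 2 by methyl in place of hydrogen on an aromatic carbon. For the measured compounds named here, the only measured step, a step that the two limits leave unreadable from compound 1 to compound 2, bears on this change merely as a warning: an exchange on the same kind of aromatic carbon did not move either value off the limit. Going by the values given here, with no sized step to build on, the step from compound 2 to compound 3 is expected to show nothing beyond the scatter, that is a step that the limit leaves unreadable from compound 2 to compound 3. Compound 3 is therefore estimated at 70000 nM, within 20000 nM to 300000 nM, and will most likely be reported once more as a limit in this assay.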

Compound 3, half-maximal inhibitory concentration: > 50000 nM
Compound 3: no number, only a limit; the forecaster's own chance of this, stated with the estimate: 85%; the middle value does not contradict the limit.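

Compound 3 gives > 50000 nM in this assay, which is a limit and not a number. Its steps from compound 1 and compound 2 therefore cannot be read, and all three compounds stay at the same limit: the limit of > 50000 nM in this assay, at which 3 of the 3 values shown sit.

The compounds shown leave open how chloro, hydrogen and methyl at this place compare, as none gives a number.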